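The source may hold more compounds than are shown below. What is called first, only, known or untested is meant among the compounds shown, and "the series" means these compounds.

Measured to date in a functional assay on L1210 cells (Mus musculus) for antiproliferative activity; on this read-out lower numbers stand for an effect already at smaller amounts and higher numbers for an effect only at larger amounts of compound:
compound 1, `CCCCCCCCCCCCO/N=C(\CCCCCC)c1cc(OC)c2c(c1OC)C(=O)C=CC2=O`, gives 0.193 ug/mL
compound 2, `CCCCCC/C(=N\OCCC)c1cc(OC)c2c(c1OC)C(=O)C=CC2=O`, gives 0.166 ug/mL
compound 3, `CCCCCCCCCCCCO/N=C/c1cc(OC)c2c(c1OC)C(=O)C=CC2=O`, gives 0.311 ug/mL

All three values lie within the usual scatter of one another in this assay, so no order among them is claimed. Compound 4, `CCCO/N=C/c1cc(OC)c2c(c1OC)C(=O)C=CC2=O`, is not yet measured. It is derived from compound 3 by hydrogen in place of nonyl on a saturated chain carbon, three bonds along the chain from an oxygen on an unsaturated carbon. The same change, (hydrogen in place of nonyl on a saturated chain carbon, three bonds along the chain from an oxygen on an unsaturated carbon), separates compound 1 from compound 2, where it gave a 1.2-fold lower number from compound 1 to compound 2 (0.07 log units; within the scatter). The difference between the cores of compound 3 and compound 1 is not broken down here; their two values in this assay simply sit within the scatter of each other.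

Taken together, the step from compound 3 to compound 4 is expected to be a 1.2-fold lower number from compound 3 to compound 4 (0.06 log units; within the scatter), matching the earlier one. Compound 4 is estimated at 0.27 ug/mL, with the range 0.12 ug/mL to 0.6 ug/mL.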

Compound 4, concentration for half-maximal effect: 0.107 ug/mL
Estimate against measurement, compound 4: 2.5-fold (0.40 log units) above; measured number outside the range, below it.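

In this assay, hydrogen in place of nonyl gives a 2.9-fold lower number from compound 3 to compound 4 (0.46 log units; beyond the scatter). Set beside the same change on the other core, the two steps do not separate: the same change on two cores in this assay, a 1.2-fold lower number (0.07 log units; within the scatter) from compound 1 to compound 2 and a 2.9-fold lower number (0.46 log units; beyond the scatter) from compound 3 to compound 4, 2.5-fold (0.40 log units) apart, within the scatter of two such steps. Going by these compounds alone, this gives no ground for treating the change as core-dependent, although only one of the two steps lies beyond the scatter; two steps are too few to show that its size carries over reliably from one core to another.

Still open, on these data alone, is how a chain of intermediate length, or a chain ending in an amine or a carboxylic acid, would read at this place. Also open, as far as these compounds go, is whether the change behaves alike on any further core.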